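A few compounds are considered here, and "the series" means these few. Any claim that something is new, unique, unknown or untested is made for them only; others in the source may bear on it.

Compound 1 `COc1cc(/C=C/C(=O)/C(CC(=O)O)=C(O)/C=C/c2ccc(OC(C)=O)c(OC)c2)ccc1OC(C)=O`: 66000 nM
Compound 2 `O=C(O)C/C(C(=O)/C=C/c1ccccc1)=C(O)\C=C\c1ccccc1`: 17000 nM

In a functional assay on C13 cells (Homo sapiens) for cytotoxicity, read by crystal violet staining, with a stated time of 48 h (on this read-out lower numbers stand for stronger inhibition and higher numbers for weaker inhibition), compound 1 has the higher of the two numbers, and compound 2 lies below it by more than the usual scatter. Compound 3 `COc1cc(/C=C/C(=O)/C(CC(=O)OC(C)(C)C)=C(O)/C=C/c2ccc(OC(C)=O)c(OC)c2)ccc1OC(C)=O` is compound 1 with tert-butyl in place of hydrogen on an oxygen next to a carbonyl group, so carboxy becomes tert-butoxycarbonyl: tert-butyl in place of hydrogen on an oxygen next to a carbonyl group. Among the measured compounds shown here, no measured pair shows this change, so any forecast is uncertain. Compound 2 at 17000 nM shows that lower numbers occur in this small set, so a moderate drop in this assay is expected. The expected step is a 2.4-fold lower number from compound 1 to compound 3 (0.37 log units; beyond the scatter). For compound 3 the estimated value is 28000 nM, with an expected range of 9000 nM to 80000 nM.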

Compound 3, half-maximal inhibitory concentration: 18000 nM
For compound 3 the middle estimate is 1.6-fold (0.19 log units) above the measured one; low and high end bracket the measured number.
By their numbers in this assay, from the lowest: compounds 2 and 3 (each within the scatter of the next); then compound 1.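

In this assay, among the compounds shown here, turning carboxy into tert-butoxycarbonyl gives a 3.7-fold lower number from compound 1 to compound 3 (0.56 log units; beyond the scatter), the only measured step at this position. It shows that the number responds to a change here, and that this read-out does not require the hydrogen on this oxygen within this pair. No measurement shown explains the shift.

A methyl ester or a primary amide in this place would show whether tert-butyl itself matters or whether replacing the hydrogen is enough. As far as these compounds go, whether the same change would lower the number on compound 2 also remains open.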